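The source may report more compounds than this note shows. Statements on the series, on what has been measured and on what is new or still open speak of the compounds shown alone.

Compound 1 `C=CC(=O)Nc1scc(-c2ccccc2)c1C(=O)OCC`: > 30000 nM
Compound 2 `C=CC(=O)Nc1nc(-c2ccccc2Cl)cs1`: 10200 nM
Compound 3 `C=CC(=O)Nc1nc(-c2ccc(C)cc2)cs1`: 16100 nM

These results come from a functional assay on HT-29 cells (Homo sapiens) for antiproliferative activity, read by MTT assay, with a stated time of 72 h; a lower number here means a stronger inhibitor, a higher number a weaker inhibitor. The entry for compound 1 is a limit of the assay and not a number. That leaves two true numbers to compare. Compound 2, at 10200 nM, and compound 3, at 16100 nM, lie within the usual scatter of each other, so the data do not separate them.

The unmeasured compound 4 `C=CC(=O)Nc1nc(-c2ccccc2OC)cs1` is compound 2 with methoxy in place of chloro on an aromatic carbon, ortho to a large group: methoxy in place of chloro on an aromatic carbon. Within the data shown here, no two measured compounds differ in just one place, so this swap has no direct precedent here. In this assay, the expectation is therefore for no change beyond the scatter, with neither direction clearly favoured. This cautious view rests on the two numbers available: sharing its core with compound 2, compound 3 gives 16100 nM, a close match despite its different substituent. The expected change is small, and the estimated step is a 1.3-fold higher number from compound 2 to compound 4 (0.11 log units; within the scatter). For compound 4, the estimated value is 13000 nM, with an expected range of 6000 nM to 28000 nM.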

Compound 4, half-maximal inhibitory concentration: > 30000 nM
Compound 4: a limit, no number; the forecaster's own chance of this, stated with the estimate: 15%; middle value at least 2.3-fold (0.36 log units) from the limit.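

In this assay, compound 4 gives > 30000 nM, which is a limit of the assay and not a number. Among these compounds, this is the first direct comparison of two groups at this position, ortho to a large group, and putting methoxy in place of chloro gives an at least 2.9-fold higher number from compound 2 to compound 4 (0.46 log units; beyond the scatter), so the swap is not neutral here: the measurable activity of the chloro compound does not survive the change within the range that the assay can read. On these data alone, the step shows only a minimum size and its true size stays unknown, because compound 4 sits at a limit: the limit of > 30000 nM in this assay, at which 2 of the 4 values shown sit.

As far as these compounds go, with only chloro and methoxy compared at this position, it remains open whether fluoro, an amine or a carboxylic acid in the same place would keep the activity of compound 2, or whether chloro is unusual in giving a measurable number. It also remains open whether this swap would have the same effect elsewhere on the ring, as no other pair of compounds shown differs in only one place.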